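Cyclopentyl Replaces an Ester-Bearing Chain at the Ring Amine

The source may report more compounds than this note shows. Statements on the series, on what has been measured and on what is new or still open speak of the compounds shown alone.

The measured compounds and their numbers:
Compound 1, `CC(C)(C)C[N+]1(C)CCc2c(sc(NC(=O)Nc3ccc(Cl)cc3)c2C(N)=O)C1`, in a functional assay (strain AB) with Danio rerio as the target, read by microscopy, with a stated time of 1 h (a higher number here means that more compound is needed for the effect, a lower number that less compound is needed), gives 290 nM.
Compound 2, `CC[N+]1(C)CCc2c(sc(NC(=O)Nc3ccc(Cl)cc3)c2C(N)=O)C1`, in this assay gives 1960 nM.
Compound 3, `CC(C)(C)OC(=O)CCCC[N+]1(C)CCc2c(sc(NC(=O)Nc3ccc(Cl)cc3)c2C(N)=O)C1`, in this assay gives 140 nM.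

Compound 3 stands lowest of the three. Its nearest neighbour is compound 1, as the step of a 2.1-fold lower number from compound 1 to compound 3 (0.32 log units; beyond the scatter) shows, and the widest gap is to compound 2, seen in a 14-fold lower number from compound 2 to compound 3 (1.15 log units; beyond the scatter).

Compound 4, `C[N+]1(CC2CCCC2)CCc2c(sc(NC(=O)Nc3ccc(Cl)cc3)c2C(N)=O)C1`, has not yet been measured. Its difference from compound 3 is cyclopentyl in place of 3-(tert-butoxycarbonyl)propyl on a saturated chain carbon bound to an amine nitrogen in a ring.

Among the compounds with values here, two measured steps bear on this. The step of a 6.8-fold higher number from compound 1 to compound 2 (0.83 log units; beyond the scatter) shows that a small group on this carbon costs potency, and a 2.1-fold lower number from compound 1 to compound 3 (0.32 log units; beyond the scatter) shows the ester-bearing chain gains modestly over tert-butyl. Cyclopentyl, a five-membered ring of carbon only, resembles the tert-butyl of compound 1 in size more than it resembles the chain of compound 3, and no measured compound carries a ring at this place. A modest rise in this assay is therefore expected for compound 4, of about a 2.1-fold higher number from compound 3 to compound 4 (0.33 log units; beyond the scatter). The estimate for compound 4 is 300 nM, expected to lie between 120 nM and 750 nM.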

Compound 4, half-maximal effective concentration: 200 nM
The estimate for compound 4 lay 1.5-fold (0.18 log units) above the measured number, and the stated range covers the measured number.
By their numbers in this assay, from the lowest: compounds 3, 4 and 1 (each within the scatter of the next, the first and the last beyond it); then compound 2.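

In this assay the cyclopentyl group holds the level of the much longer ester-bearing chain, with a 1.4-fold higher number from compound 3 to compound 4 (0.15 log units; within the scatter) as the step, so the oxygen atoms of the 3-(tert-butoxycarbonyl)propyl group are not required for a number of this order at this place. Cyclopentyl also reads level with tert-butyl, as a 1.5-fold lower number from compound 1 to compound 4 (0.16 log units; within the scatter) shows, whereas the step from methyl is a 9.8-fold lower number from compound 2 to compound 4 (0.99 log units; beyond the scatter) and keeps compound 2 clearly apart from the other compounds. A ring of carbon only thus joins a branched group and an ester-bearing chain in a narrow band at this place, though compound 1 and compound 3, at its two ends, remain separated by a 2.1-fold lower number from compound 1 to compound 3 (0.32 log units; beyond the scatter) and compound 2 stands outside it.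

The compounds shown leave open whether a larger ring such as cyclohexyl, or a chain ending in a carboxylic acid or an amine in place of the tert-butyl ester, would stay in this band in this assay and whether these groups read alike for a shared reason. No supporting evidence is available to explain the result.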